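Adding chloro to the benzyl group of compound 3

The compounds below may be only part of what the source reports. "The series", "measured", "known", "first", "only" and "open" are said of these compounds alone.

Measured in an ADME assay on HEK-293T cells (Homo sapiens) for inhibition, read by CCK-8 assay, with a stated time of 48 h; on this read-out lower numbers stand for stronger inhibition and higher numbers for weaker inhibition:
compound 1 `COc1ccc(S(=O)(=O)Nc2cccc(/C=C(\C#N)C(=O)Nc3nnc(-c4cccs4)s3)c2)cc1`: > 20000 nM (a limit)
compound 2 `COc1ccc(Cc2nnc(NC(=O)/C(C#N)=C/c3ccccc3OS(=O)(=O)c3ccc(OC)cc3)s2)cc1`: > 50000 nM (a limit)
compound 3 `COc1ccc(S(=O)(=O)Oc2ccccc2/C=C(\C#N)C(=O)Nc2nnc(Cc3ccccc3)s2)cc1`: > 50000 nM (a limit)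

Compound 3 has only a limit, > 50000 nM, and no number. It sits at the limit of > 50000 nM in this assay, at which 2 of the 3 values shown sit, together with compound 2. Compound 1 sits at the limit of > 20000 nM in this assay, at which 1 of the 3 values shown sits.

Compound 4 `COc1ccc(S(=O)(=O)Oc2ccccc2/C=C(\C#N)C(=O)Nc2nnc(Cc3ccc(Cl)cc3)s2)cc1` has not yet been measured. It differs from compound 3 by chloro in place of hydrogen on an aromatic carbon, para to a large group, which turns benzyl to 4-chlorobenzyl: chloro in place of hydrogen on an aromatic carbon.

Going by the values given here, one measured step bears on this change: a step that the two limits leave unreadable from compound 2 to compound 3, with hydrogen in place of methoxy on an aromatic carbon. It offers no size to carry over, so the expectation rests on the limits alone. No change beyond the scatter is expected in this assay, and no direction can be given. The expected size is a number no higher from compound 3 to compound 4 (the limit leaves the size open). For compound 4 the estimate is 50000 nM. The expected range for compound 4 runs from 20000 nM to 100000 nM, and a reading reported only as a limit is likely.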

Compound 4, half-maximal inhibitory concentration: > 50000 nM
Compound 4: only a limit was reported (the forecaster's own chance of this, stated with the estimate: 75%); the middle value sits exactly at the limit.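

In this assay compound 4 gives > 50000 nM, which is a limit and not a number. Its steps from compound 3 and compound 2 cannot be read, since all three carry only limits. The compounds shown leave open whether 4-chlorobenzyl in place of benzyl changes the read-out at all.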